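Primary amide for methyl ester on a shared core

A few compounds are considered here, and "the series" means these few. Any claim that something is new, unique, unknown or untested is made for them only; others in the source may bear on it.

Measured compounds:
- compound 1, `COC(=O)c1cccc(C(=O)N2CCC(N(C3CC3)S(=O)(=O)c3cccc(C(F)(F)F)c3)CC2)c1`: "not determined" (no result reported)
- compound 2, `O=C(c1cccc(OC(F)(F)F)c1)N1CCC(N(C2CC2)S(=O)(=O)c2cccc(C(F)(F)F)c2)CC1`: 60%
- compound 3, `CS(=O)(=O)c1cccc(C(=O)N2CCC(N(C3CC3)S(=O)(=O)c3cccc(C(F)(F)F)c3)CC2)c1`: "not determined" (no result reported)

Three compounds share one core and differ only in the aryl group on the carbonyl carbon attached to the ring nitrogen. In an assay on cells for inhibition of Voltage-dependent L-type calcium channel subunit alpha-1C (Homo sapiens), read by FLIPR and calcium flux, tested at 1 uM (on this read-out lower numbers stand for a weaker effect and higher numbers for a stronger effect at the one concentration tested), compound 2 gives 60%. Within the data shown here, for compound 1 no number is available in this assay, and the same holds for compound 3, so compound 1 cannot be placed on the scale at all; the only anchor is compound 2.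

The unmeasured compound 4, `NC(=O)c1ccc(C(=O)N2CCC(N(C3CC3)S(=O)(=O)c3cccc(C(F)(F)F)c3)CC2)cc1`, differs from compound 1 in one place: 4-carbamoylphenyl in place of 3-(methoxycarbonyl)phenyl on a carbonyl carbon. Among the measured compounds shown here, no step between measured compounds relates to this change, so the size of the step in this assay from compound 1 to compound 4 cannot be read from data; any direction is possible, and a shift beyond the usual scatter would not be surprising.

Compound 4 is therefore expected to show roughly 40% in this assay, estimated to fall between 10% and 75%.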

Compound 4, a percentage reported as inhibition, at one concentration (the size of the read-out at that concentration, not a potency): 0%
The estimate for compound 4 lay 40 percentage points above the measured number; measured number outside the range, below it.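

The group on this carbonyl carbon decides much of the read-out: with the rest of the core unchanged, 4-carbamoylphenyl in place of 3-(trifluoromethoxy)phenyl gives a number 60 percentage points lower from compound 2 to compound 4 (beyond the scatter) in this assay. Among these compounds, this is the first step, and it shows that the shared core alone does not secure an effect at the one concentration tested. Steps to compound 4 from compound 1 and compound 3 cannot be read, and nothing available accounts for the loss.

The compounds shown leave open whether the step follows from the change of group or from its place on the ring, since both differ between compound 2 and compound 4. Nor do they show how a 3-carbamoylphenyl group, a 4-(trifluoromethoxy)phenyl group or a carboxylic acid on that ring would read.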